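One Small Swap: Methoxy to Hydroxy

This account rests on a few compounds, and the source may have more. Where it says the series, first, only, none or still open, it means among the compounds named here.

For the measured compounds named here, only two compounds have results so far in a functional assay on SGC-7901 cells (Homo sapiens) for cytotoxicity, read by MTT assay, with a stated time of 48 h; a higher number here means a weaker inhibitor, a lower number a stronger inhibitor. Compound 1 (`COc1ccc(/C=C/C(=O)c2cc3ccccc3oc2=O)cc1`) was reported as "not active" (no number reported), which leaves no number to compare. Going by the values given here, compound 2 (`COc1ccc(C2CC(c3cc4ccccc4oc3=O)=NN2C(C)=O)cc1`) gave 48.7 ug/mL, the only number available, so there is nothing yet to rank it against.

The untested compound 3 (`CC(=O)N1N=C(c2cc3ccccc3oc2=O)CC1c1ccc(O)cc1`) differs from compound 2 in one place: hydrogen in place of methyl on an oxygen on an aromatic ring. This puts hydrogen in place of methyl on an oxygen on an aromatic ring, turning 4-methoxyphenyl to 4-hydroxyphenyl.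

Among the compounds with values here, no two measured compounds differ in just one place, so the data give no guide to how much a single change can shift the result in this assay. The expected step of a 1.1-fold lower number from compound 2 to compound 3 (0.03 log units; within the scatter) therefore stays within the usual scatter of repeated measurements, and no firm direction is expected. Within the data shown here, this expectation rests on compound 2 at 48.7 ug/mL, the only measured compound with the same core and a number. The estimated value for compound 3 is 45 ug/mL, with an expected range of 20 ug/mL to 100 ug/mL.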

Compound 3, half-maximal inhibitory concentration: 35.9 ug/mL
Compound 3: the middle estimate sits 1.3-fold (0.10 log units) above what was measured; the measured number falls inside the stated range.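

For the compounds shown here, the swap of methoxy to hydroxy gives the first step between two measured compounds that differ in one place in this assay: a 1.4-fold lower number from compound 2 to compound 3 (0.13 log units; within the scatter). At this position, on an oxygen on an aromatic ring, the methyl can therefore be replaced by hydrogen without a shift that this read-out can tell apart from the ordinary spread of repeated measurements, so the cytotoxic effect seen with compound 2 is retained in compound 3 at a comparable level. The earlier compounds could not show this, since no measured pair differed in just one place, and no measurement shown here offers an explanation for the outcome.

Going by these compounds, this single step covers only methyl and hydrogen on that oxygen, so it remains open whether a longer chain such as butyl on the same oxygen, or an amine or a carboxylic acid in place of the hydroxy, would move the number beyond the scatter. It also leaves open whether changes elsewhere on the shared core would matter more than this one.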